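A few compounds are considered here, and "the series" means these few. Any claim that something is new, unique, unknown or untested is made for them only; others in the source may bear on it.

Going by the values given here, in a functional assay on MDA-MB-231 cells (Homo sapiens) for antiproliferative activity, read by MTT assay, with a stated time of 72 h (on this read-out higher numbers stand for weaker inhibition and lower numbers for stronger inhibition), three compounds have numbers so far. Compound 1 `COc1cc(Nc2ccc3c(c2)S(=O)(=O)C=C3)cc(OC)c1OC` gives 1430 nM, compound 2 `O=S1(=O)C=Cc2cccc(Nc3cccc(C(F)(F)F)c3)c21` gives 680 nM, and compound 3 `O=S1(=O)C=Cc2cccc(Nc3ccc(OC(F)(F)F)cc3)c21` gives 2100 nM. The values of compound 3 and compound 1 lie within the usual scatter of repeat measurements, so they cannot be told apart. The gap between compound 3 and compound 2 goes beyond that scatter, with compound 3 the weaker inhibitor.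

Compound 4 `O=S1(=O)C=Cc2cccc(Nc3ccc(Cl)cc3)c21` differs from compound 3 in one place: chloro in place of trifluoromethoxy on an aromatic carbon. Among the compounds with values here, no two measured compounds differ in only one place, so nothing here shows directly what such a swap does. The three measured values do sit fairly close together, so only a modest shift is expected, none beyond the scatter, leaning towards a lower number. The estimated change is a 1.5-fold lower number from compound 3 to compound 4 (0.18 log units; within the scatter). For compound 4 the estimated value is 1400 nM, with an expected range from 550 nM to 3500 nM.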

Compound 4, half-maximal inhibitory concentration: 1210 nM
For compound 4 the middle estimate is 1.2-fold (0.06 log units) above the measured one, within the range that was stated.
By their numbers in this assay, from the lowest: compounds 2, 4, 1 and 3 (each within the scatter of the next, the first and the last beyond it).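

This is the first pair shown that differs in one place only, so a swap on an aromatic carbon para to a large group can now be read directly: in this assay, chloro in place of trifluoromethoxy gives a 1.7-fold lower number from compound 3 to compound 4 (0.24 log units; within the scatter). Five heavy atoms leave, one enters and a hydrogen-bond acceptor is lost, yet the two compounds cannot be told apart on this read-out, so this position accepts either group without a clear difference. No measured property of these groups bears on this result.

From the compounds shown here alone, it remains open how this position would respond to a different kind of group, such as an amine or a carboxylic acid. Going by these compounds, it is also open whether chloro and trifluoromethoxy would compare in the same way elsewhere on the ring or on the core of compound 1.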